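Reversing the urea to amide swap on the trifluoromethyl arm

The source may report more compounds than this note shows. Statements on the series, on what has been measured and on what is new or still open speak of the compounds shown alone.

Of the compounds shown here, three sharing one core have been measured in a functional assay on MOLT-4 cells (Homo sapiens) for inhibition, read by sulforhodamine B assay, with a stated time of 48 h, tested at 10 uM; on this read-out higher numbers stand for a weaker effect at the one concentration tested and lower numbers for a stronger effect. Compound 1 `COc1cc(Cl)cc(-c2nn(-c3cccc(NC(=O)c4ccc(Cl)c(Cl)c4)c3)cc2-c2ccncc2)c1` gives 54.9%. Compound 2 `COc1cc(Cl)cc(-c2nn(-c3cccc(NC(=O)Nc4ccc(Cl)c(Cl)c4)c3)cc2-c2ccncc2)c1`, carrying a urea instead, gives -16.1%, and compound 3 `COc1cc(Cl)cc(-c2nn(-c3cccc(NC(=O)Nc4cccc(C(F)(F)F)c4)c3)cc2-c2ccncc2)c1` gives -9.16%. Compound 3 thus stands second highest of the three: its nearest neighbour is compound 2, the step being a number 6.9 percentage points higher from compound 2 to compound 3 (within the scatter), while the furthest is compound 1, with a number 64.1 percentage points lower from compound 1 to compound 3 (beyond the scatter).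

Compound 4 `COc1cc(Cl)cc(-c2nn(-c3cccc(NC(=O)c4cccc(C(F)(F)F)c4)c3)cc2-c2ccncc2)c1` differs from compound 3 in one place, (3-(trifluoromethyl)phenyl in place of (3-(trifluoromethyl)phenyl)amino on a carbonyl carbon). The relevant precedent is the step of a number 71 percentage points lower from compound 1 to compound 2 (beyond the scatter), which is the same exchange run in the opposite direction on the dichlorophenyl arm, and the step of a number 64.1 percentage points lower from compound 1 to compound 3 (beyond the scatter), which combines that exchange with the change of aryl group. Both were large drops when the amide became a urea, so restoring the amide is expected to bring a large rise, an estimated a number 61.2 percentage points higher from compound 3 to compound 4 (beyond the scatter). Compound 4 is therefore expected to give 52%, with a range from 28% to 76%.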

Compound 4, a percentage reported as activity, at one concentration (the size of the read-out at that concentration, not a potency): 29%
Beside the measured number, compound 4's estimate is 23 percentage points above it, within the range that was stated.
By their numbers in this assay, from the lowest: compounds 2 and 3 (each within the scatter of the next); then compound 4; then compound 1.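

Compound 4 shows that the urea-to-amide exchange weakens the effect in this assay on the trifluoromethyl arm as well, with a number 38.2 percentage points higher from compound 3 to compound 4 (beyond the scatter), and with a number 45.1 percentage points higher from compound 2 to compound 4 (beyond the scatter) when the aryl group changes too. It also shows that the aryl group on the carbonyl carbon can count: among the amides there is a number 25.9 percentage points lower from compound 1 to compound 4 (beyond the scatter), whereas among the ureas the corresponding step, a number 6.9 percentage points higher from compound 2 to compound 3 (within the scatter), stays within the scatter. No measurement given here explains either step.

The compounds shown leave open how a thiourea or a sulfonamide would read in place of the urea or the amide. They also leave open whether the gap between urea and amide would persist with a cyclohexyl group in place of the aryl ring.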